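The source may report more compounds than this note shows. Statements on the series, on what has been measured and on what is new or still open speak of the compounds shown alone.

Compound 2 `CO/C(O)=C1\C(C)=NC(C)=C(C(=O)OCCCN2C(=O)c3ccccc3S2(=O)=O)C1c1ccccc1Cl` gives 0.0867 h in a functional assay on aorta with Voltage-dependent L-type calcium channel subunit alpha-1C (Oryctolagus cuniculus) as the target (a lower number here means that the compound disappears faster, a higher number that the compound lasts longer), the lowest of the two numbers in hand; compound 1 `CC1=NC(C)=C(C(=O)OCCCN2C(=O)c3ccccc3S2(=O)=O)C(c2ccccc2[N+](=O)[O-])/C1=C(\O)OC(C)C` gives 0.145 h, a gap within the scatter, so neither is called the shorter-lived of the pair. Compound 3 `CC1=NC(C)=C(C(=O)OCCCN2C(=O)c3ccccc3S2(=O)=O)C(c2ccccc2Cl)/C1=C(\O)OC(C)C` differs from compound 2 by isopropyl in place of methyl on an oxygen on an unsaturated carbon. Within the data shown here, no step between measured compounds isolates this change, and the change is expected to move this assay by no more than the scatter in either direction, which is the step of a 1.4-fold higher number from compound 2 to compound 3 (0.14 log units; within the scatter). Compound 3 is expected to give 0.12 h, with a range of 0.06 h to 0.25 h.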

Compound 3, half-life: 0.08 h
The estimate for compound 3 lay 1.5-fold (0.18 log units) above the measured number; low and high end bracket the measured number.
By their numbers in this assay, from the lowest: compounds 3, 2 and 1 (each within the scatter of the next).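

In this assay isopropyl in place of methyl on an oxygen on an unsaturated carbon gives a 1.1-fold lower number from compound 2 to compound 3 (0.03 log units; within the scatter) and so does not separate the two groups at this place. Chloro in place of nitro on an aromatic carbon gives a 1.8-fold lower number from compound 1 to compound 3 (0.26 log units; within the scatter) and likewise leaves the two groups unseparated, so compound 3 now links compound 1 and compound 2 through single changes. No measurement in hand speaks to the origin of either step. Open, on these data alone, is whether a benzyl group on this oxygen, or a nitrile on that aromatic carbon, would move the half-life beyond the scatter.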